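The source may report more compounds than this note shows. Statements on the series, on what has been measured and on what is new or still open speak of the compounds shown alone.

Compound 1 `Cc1cccc(-n2cc(-c3ccc(NS(=O)(=O)c4c[nH]c(=O)[nH]c4=O)cc3)nn2)c1`: 28300 nM
Compound 2 `O=c1[nH]cc(S(=O)(=O)Nc2ccc(-c3cn(-c4cccc(F)c4)nn3)cc2)c(=O)[nH]1`: "not toxic" (no number reported)

In an ADME assay on GES1 cells (Homo sapiens) for cytotoxicity, read by MTT assay, with a stated time of 24 h (on this read-out lower numbers stand for higher toxicity in this test and higher numbers for lower toxicity in this test), compound 1 gives 28300 nM. In this assay, going by the values given here, compound 2 is reported as "not toxic" (no number reported), so no single number fixes where compound 2 stands, and no step from compound 1 to compound 2 can be sized. Compound 3 `O=c1[nH]cc(S(=O)(=O)Nc2ccc(-c3cn(-c4cccc(Cl)c4)nn3)cc2)c(=O)[nH]1` differs from compound 2 by chloro in place of fluoro on an aromatic carbon. Among the compounds with values here, no measured step of this kind is available, so no shift beyond the scatter is expected in either direction. Compound 3 is expected to give about 40000 nM in this assay, between 15000 nM and 150000 nM.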

Compound 3, half-maximal cytotoxic concentration: 7570 nM
Beside the measured number, compound 3's estimate is 5.3-fold (0.72 log units) above it; the measured number lies below the stated range.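

Chloro in place of methyl on this aromatic carbon gives a 3.7-fold lower number from compound 1 to compound 3 (0.57 log units; beyond the scatter) in this assay and so shows that the number at this position does respond to a single-atom change. Compound 3 also gives the position a second number, whereas compound 2, with its 3-fluorophenyl, is reported only as "not toxic", so the step from fluoro to chloro cannot be read. Nothing shown explains the shift.

The compounds shown leave open how a methoxy group, an amine or a carboxylic acid would read at this position.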